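Dichloroacetamide biaryls: fluoro to trifluoromethyl steps

A few compounds are considered here, and "the series" means these few. Any claim that something is new, unique, unknown or untested is made for them only; others in the source may bear on it.

Compound 1 `O=C(Nc1cccc(-c2cccc(F)c2)c1)C(Cl)Cl` and compound 2 `O=C(Nc1cccc(-c2cccc(C(F)(F)F)c2)c1)C(Cl)Cl` share one core. In a functional assay on A549 cells (Homo sapiens) for cytotoxicity, read by MTT assay, with a stated time of 68 h (a lower number here means a stronger inhibitor, a higher number a weaker inhibitor), compound 1 gives 9530 nM and compound 2 gives 18500 nM. The change between them is trifluoromethyl in place of fluoro on an aromatic carbon, and it made a 1.9-fold higher number from compound 1 to compound 2 (0.29 log units; within the scatter).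

Compound 3 `O=C(Nc1cccc(-c2ccc(F)cc2)c1)C(Cl)Cl` has the same atoms as compound 1 joined differently; the difference between the two cores is not broken down here. In this assay compound 3 gives 7840 nM. Its gap to compound 1 lies within the scatter, its gap to compound 2 beyond it.

Compound 4 `O=C(Nc1cccc(-c2ccc(C(F)(F)F)cc2)c1)C(Cl)Cl` is not yet measured. It differs from compound 3 by trifluoromethyl in place of fluoro on an aromatic carbon. This is the same kind of change as from compound 1 to compound 2, but not the same: there the entering group sits meta to a large group, here para to a large group. For the measured compounds named here, only one earlier step of this kind is known, so the expectation rests on it alone. Because a 1.9-fold higher number from compound 1 to compound 2 (0.29 log units; within the scatter) is that single precedent, the expected step is a 1.9-fold higher number from compound 3 to compound 4 (0.28 log units; within the scatter). Compound 4 is thus estimated at 15000 nM in this assay, with a likely range from 7000 nM to 32000 nM.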

Compound 4, half-maximal inhibitory concentration: 23500 nM
The estimate for compound 4 lay 1.6-fold (0.19 log units) below the measured number, and the stated range covers the measured number.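

In this assay, trifluoromethyl in place of fluoro on an aromatic carbon, para to a large group, gives a 3.0-fold higher number from compound 3 to compound 4 (0.48 log units; beyond the scatter), while the same exchange on the core of compound 1 gives a 1.9-fold higher number from compound 1 to compound 2 (0.29 log units; within the scatter). Both steps point towards a higher number, and their sizes cannot be told apart on the data at hand: the same change on two cores in this assay, a 1.9-fold higher number (0.29 log units; within the scatter) from compound 1 to compound 2 and a 3.0-fold higher number (0.48 log units; beyond the scatter) from compound 3 to compound 4, 1.5-fold (0.19 log units) apart, within the scatter of two such steps. For the compounds shown here, this supports carrying the change between these two cores as a rough guide, but only the step on the core of compound 3 lies beyond the scatter, and two cores do not show that the step would hold on a third core or at another place on the ring.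

The compounds shown carry only fluoro or trifluoromethyl on the second aromatic ring, and all keep the dichloroacetamide. On these data alone, how an amine, a carboxylic acid or a longer alkyl chain at that place would read in this assay remains open, as does the effect of replacing the dichloroacetamide.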